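Carbonyl carbon change from compound 2 to compound 4

The source may report more compounds than this note shows. Statements on the series, on what has been measured and on what is new or still open speak of the compounds shown alone.

Among the compounds with values here, the series so far holds compound 1 `CNC(=O)/C=C/c1ccncc1-c1ccc2ccccc2c1`, compound 2 `CCOC(=O)/C=C/c1ccncc1-c1ccc2ccccc2c1` and compound 3 `CNC(=O)CCc1ccncc1-c1ccc2ccccc2c1`. In a functional assay on A549 cells (Homo sapiens) for inhibition, read by sulforhodamine B assay, with a stated time of 72 h (on this read-out higher numbers stand for weaker inhibition of growth and lower numbers for stronger inhibition of growth), compound 2 gives 5380 nM, compound 1 gives 6620 nM and compound 3 gives 10400 nM. Compound 2 thus stands within the scatter of both others, and no order can be read among the three.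

The next structure is compound 4 `COC1CN(C(=O)/C=C/c2ccncc2-c2ccc3ccccc3c2)C1`, which carries 3-methoxyazetidin-1-yl in place of ethoxy on a carbonyl carbon. The most relevant measurement is the other exchange at this carbon, ethoxy in place of methylamino, which gave a 1.2-fold lower number from compound 1 to compound 2 (0.09 log units; within the scatter). The remaining steps, a 1.6-fold higher number from compound 1 to compound 3 (0.20 log units; within the scatter) and a 1.9-fold higher number from compound 2 to compound 3 (0.29 log units; within the scatter), bear less directly and also stay within the scatter. Within the data shown here, no measured compound carries 3-methoxyazetidin-1-yl, so the data offer only weak support for any forecast. Among the measured compounds shown here, with a 1.2-fold lower number from compound 1 to compound 2 (0.09 log units; within the scatter) as the sole step confined to this carbon, no shift beyond the scatter is expected. The expected step in this assay is a 1.1-fold higher number from compound 2 to compound 4 (0.05 log units; within the scatter). Compound 4 is estimated at 6000 nM, with an expected range of 2500 nM to 14000 nM.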

Compound 4, concentration for 50% growth inhibition: > 10000 nM
Compound 4 was reported as a limit; the forecaster's own chance of this, stated with the estimate: 3%; at least 1.6-fold (0.22 log units) between middle value and limit.
By their numbers in this assay, from the lowest: compounds 2, 1 and 3 (each within the scatter of the next).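

In this assay compound 4 gives a value that is a limit of the assay and not a number: the limit of > 10000 nM in this assay, at which 1 of the 4 values shown sits. Read as a floor, the exchange of ethoxy for 3-methoxyazetidin-1-yl on the carbonyl carbon gives an at least 1.8-fold higher number from compound 2 to compound 4 (0.26 log units; that floor lies within the scatter), and the exchange of methylamino for the same group gives an at least 1.5-fold higher number from compound 1 to compound 4 (0.17 log units; that floor lies within the scatter). The earlier exchange at this carbon stayed within the scatter, and the first group with a four-membered non-aromatic ring there gives only a floor, so neither step is shown to go beyond the scatter, while the true number may lie further up and the size of the change stays unknown.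

On these data alone, it remains open how far the number of compound 4 lies past the limit and whether any real step at this carbon belongs to the four-membered ring, to the methoxy on it, or to the loss of the amide hydrogen present in compound 1. Azetidin-1-yl without the methoxy, dimethylamino or a carboxylic acid at the same carbonyl carbon would bear on these points, and none of them can be judged from the compounds shown.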